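Trifluoromethyl for Methyl on a Weakly Cytotoxic Amide

The source may report more compounds than this note shows. Statements on the series, on what has been measured and on what is new or still open speak of the compounds shown alone.

Compound 1, `Cc1ccc(-c2ccnc(C(=O)Nc3ccc(Oc4ccnc5[nH]ccc45)cc3)c2)cc1`, in a functional assay on MCF7 cells (Homo sapiens) for cytotoxicity, read by MTT assay, with a stated time of 72 h (a lower number here means a stronger inhibitor, a higher number a weaker inhibitor), gives > 10000 nM, a limit of the assay and not a number.
Compound 2, `Cc1ccc(-c2ccnc(C(=O)Nc3ccc(Oc4ccnc5[nH]ccc45)c(F)c3)c2)cc1`, gives 8430 nM.

Compound 2 thus holds the only number shown, and the value for compound 1 is a limit (the limit of > 10000 nM in this assay, at which 1 of the 2 values shown sits). Compound 3, `O=C(Nc1ccc(Oc2ccnc3[nH]ccc23)c(F)c1)c1cc(-c2ccc(C(F)(F)F)cc2)ccn1`, differs from compound 2 by trifluoromethyl in place of methyl on an aromatic carbon. Among the compounds with values here, the single measured step, an at least 1.1-fold lower number from compound 1 to compound 2 (0.07 log units; that floor lies within the scatter), concerns another place and lies within the scatter. Within the data shown here, no measured step covers methyl to trifluoromethyl. For compound 3 the expected step is a 1.3-fold lower number from compound 2 to compound 3 (0.11 log units; within the scatter), none beyond the scatter. Compound 3 is estimated at 6500 nM, ranging from 1500 nM to 25000 nM.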

Compound 3, half-maximal inhibitory concentration: 8550 nM
Beside the measured number, compound 3's estimate is 1.3-fold (0.12 log units) below it, within the range that was stated.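

In this assay, within the data shown here, the step of a 1.0-fold higher number from compound 2 to compound 3 (0.01 log units; within the scatter) is the first measured reading of trifluoromethyl in place of methyl, here on an aromatic carbon para to a large group. At this place the two groups cannot be told apart, since compound 2 and compound 3 lie within the scatter of each other. Nothing shown bears on a cause for this result.

On these data alone, whether an amine, a carboxylic acid or a methoxy group at this place would read apart from these two remains open. So does whether the same exchange reads alike on the core of compound 1, which lacks the fluoro.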